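Working notes on a corticotropin-releasing factor receptor series

A few compounds are considered here, and "the series" means these few. Any claim that something is new, unique, unknown or untested is made for them only; others in the source may bear on it.

Measured so far, in an assay on cell membranes for displacement of a labelled ligand from corticotropin-releasing factor receptor 1 (Rattus norvegicus); a lower number here means a stronger inhibitor, a higher number a weaker inhibitor:
- compound 1 `COc1ccc(-c2c(C)nn3c(NC4CCC4)nc(C)nc23)c(C)c1` gives 24.6 nM
- compound 2 `CCN(CC)c1nc(C)nc2c(-c3c(C)cc(OC)cc3OC)c(C)nn12` gives 1.2 nM
- compound 3 `CCC(CC)Nc1nc(C)nc2c(-c3cc(F)c(OC)cc3C)c(C)nn12` gives 1.9 nM

Compound 2 has the lowest number of the three, but the gap to compound 3 is within the scatter; only compound 1 sits clearly beyond it.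

Compound 4 `C=CCN(CC=C)c1nc(C)nc2c(-c3c(C)cc(OC)cc3OC)c(C)nn12` is not yet measured. It differs from compound 2 by diallylamino in place of diethylamino on an aromatic carbon. For the measured compounds named here, no measured pair shows this change, so nothing tells its size in this assay; a step no larger than the scatter is expected, in either direction. Compound 4 is therefore estimated at 2 nM, with a range of 0.6 nM to 7 nM, the expected step being a 1.7-fold higher number from compound 2 to compound 4 (0.22 log units; within the scatter).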

Compound 4, half-maximal inhibitory concentration: 1 nM
Estimate against measurement, compound 4: 2.0-fold (0.30 log units) above; measured number inside the range.
By their numbers in this assay, from the lowest: compounds 4, 2 and 3 (each within the scatter of the next); then compound 1.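

On the aromatic carbon between two ring nitrogen atoms, diallylamino in place of diethylamino gives a 1.2-fold lower number from compound 2 to compound 4 (0.08 log units; within the scatter) in this assay. This position therefore accepts a larger group, with 7 heavy atoms against 5 and 2 double bonds outside aromatic rings, and compound 2 and compound 4 cannot be told apart. Going by these compounds, whether a ring such as morpholine or pyrrolidine, or a longer chain such as dipropylamino, is accepted here as well remains open. No other data in hand bear on the reason for this result.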